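The source may hold more compounds than are shown below. What is called first, only, known or untested is meant among the compounds shown, and "the series" means these compounds.

Measured so far:
compound 1, `CCCCN(C)c1cc(C(F)(F)F)ccc1CNC(=O)C(C)c1ccc(NS(C)(=O)=O)c(F)c1`, in an assay on CHO cells for antagonist activity at transient receptor potential cation channel subfamily V member 1 (Homo sapiens), read by FLIPR (on this read-out higher numbers stand for weaker inhibition and lower numbers for stronger inhibition), compound 1 gives 1.2 nM
compound 2, `CC(C(=O)NCc1ccc(C(F)(F)F)cc1OCc1ccccc1)c1ccc(NS(C)(=O)=O)c(F)c1`, in this assay compound 2 gives 0.9 nM

Compound 2 holds the lowest of the two numbers, and its nearest neighbour is compound 1 with a 1.3-fold lower number from compound 1 to compound 2 (0.12 log units; within the scatter), so the two compounds cannot be told apart on this read-out. Compound 3, `CCCCSc1cc(C(F)(F)F)ccc1CNC(=O)C(C)c1ccc(NS(C)(=O)=O)c(F)c1`, is not yet measured; it differs from compound 2 by butylsulfanyl in place of benzyloxy on an aromatic carbon. For the measured compounds named here, the only measured step that touches this position is the one from compound 1 to compound 2, which exchanged one substituent for another at the same aromatic carbon and stayed within the scatter. Compound 3 shares the butyl chain of compound 1, and both measured compounds are strong in this assay. The expectation for compound 3 is therefore a step of about a 1.7-fold higher number from compound 2 to compound 3 (0.22 log units; within the scatter), no further than the scatter in either direction. The estimate for compound 3 in this assay is 1.5 nM, with a range from 0.5 nM to 5 nM.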

Compound 3, inhibition constant: 1.9 nM
The estimate for compound 3 lay 1.3-fold (0.10 log units) below the measured number, and the stated range covers the measured number.
By their numbers in this assay, from the lowest: compounds 2, 1 and 3 (each within the scatter of the next, the first and the last beyond it).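

In this assay, this aromatic carbon, ortho to a large group and meta to a trifluoromethyl group, now gives its first step beyond the scatter: butylsulfanyl in place of benzyloxy brings a 2.1-fold higher number from compound 2 to compound 3 (0.32 log units; beyond the scatter) and the step is modest. Butylsulfanyl in place of butyl(methyl)amino, with the butyl chain kept, stays within the scatter at a 1.6-fold higher number from compound 1 to compound 3 (0.20 log units; within the scatter) and so does not separate those two groups on this read-out. No data on hand explain the step away from benzyloxy.

Benzyloxy and butylsulfanyl differ in both the aromatic ring and the oxygen or sulfur atom, so the step cannot be assigned to either change. A butoxy or benzylsulfanyl group at this carbon would separate the two, and a shorter chain such as methylsulfanyl would test the length of the butyl chain.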